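Two inactive nucleosides and a difluoromethoxy analogue

The source may hold more compounds than are shown below. What is called first, only, known or untested is meant among the compounds shown, and "the series" means these compounds.

Compound 1, with the structure `OC[C@H]1O[C@@H](n2cnc3c(NCc4ccc(Cl)cc4Cl)ncnc32)[C@H](O)[C@@H]1O`, was tested in a functional assay on HOS cells (Homo sapiens) for antiproliferative activity, with a stated time of 72 h; a higher number here means a weaker inhibitor, a lower number a stronger inhibitor. Compound 1 gives > 166000 nM, which is a limit of the assay and not a number. Compound 2, `COc1cc(CNc2ncnc3c2ncn3[C@@H]2O[C@H](CO)[C@@H](O)[C@H]2O)cc(OC)c1O`, is the other measured compound. In this assay compound 2 gives > 166000 nM, again a limit and not a number. Compound 1 therefore stands nowhere in particular on the numbers shown: the limit of > 166000 nM in this assay, at which 2 of the 2 values shown sit, so neither measured compound gives a number to compare against.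

Compound 3, `OC[C@H]1O[C@@H](n2cnc3c(NCc4ccccc4OC(F)F)ncnc32)[C@H](O)[C@@H]1O`, has not yet been measured. It differs from compound 1 by 2-(difluoromethoxy)phenyl in place of 2,4-dichlorophenyl on a saturated chain carbon bound to a nitrogen on an aromatic ring. Among the measured compounds shown here, no measured step is available, so the author expects no change beyond the scatter in this assay and that the step of a number no higher from compound 1 to compound 3 (the limit leaves the size open) will again end at the limit. Compound 3 is estimated at 166000 nM, with a range from 50000 nM to 500000 nM.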

Compound 3, half-maximal inhibitory concentration: > 166000 nM
Compound 3: only a limit was reported; the forecaster's own chance of this, stated with the estimate: 80%; the middle value lies on the limit itself.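

In this assay compound 3 gives > 166000 nM, a limit of the assay and not a number. Compound 1 also stands at a limit, so no step can be read between compound 1 and compound 3. The compounds shown leave open whether either group, on the shared core, allows any measurable antiproliferative potency in this assay.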